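Carbonate to Isoxazole Ether in a Platelet Factor Series

The source may report more compounds than this note shows. Statements on the series, on what has been measured and on what is new or still open speak of the compounds shown alone.

Measured compounds:
Compound 1 `C/C1=C\CC[C@@]2(C)O[C@@H]2C(=O)[C@@H]2CC[C@@H](C)[C@](C)(CC1)[C@H]2CO`; in an assay (Oryctolagus cuniculus) for inhibition of platelet-activating factor receptor (Cavia porcellus) (a higher number here means a weaker inhibitor, a lower number a stronger inhibitor), compound 1 gives 1300 nM.
Compound 2 `COC(=O)OC[C@H]1[C@H]2CC[C@@H](C)[C@]1(C)CC/C(C)=C/CC[C@@]1(C)O[C@@H]1C2=O`; in this assay compound 2 gives 26 nM.

Compound 2 stands at the lowest of the two numbers measured in this assay; its nearest neighbour is compound 1, and the step of a 50-fold lower number from compound 1 to compound 2 (1.70 log units; beyond the scatter) separates them, a large change that clearly exceeds the scatter.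

Compound 3 `C/C1=C\CC[C@@]2(C)O[C@@H]2C(=O)[C@@H]2CC[C@@H](C)[C@](C)(CC1)[C@H]2COc1ccon1` is not yet measured. It differs from compound 2 by 1,2-oxazol-3-yl in place of methoxycarbonyl on an oxygen on a saturated carbon. In words, the carbonate cap on the hydroxymethyl oxygen is exchanged for a small aromatic ring, so the oxygen becomes an aryl ether instead of part of a carbonate.

Within the data shown here, no measured step covers this exchange. Among the measured compounds shown here, the only step available, a 50-fold lower number from compound 1 to compound 2 (1.70 log units; beyond the scatter), shows that placing methoxycarbonyl on that oxygen in place of hydrogen lowered the number strongly, so the oxygen substituent in this position matters a great deal. On these data alone, whether an aromatic ring with the same count of acceptors can match the carbonate is unknown; the expectation for compound 3 in this assay is therefore a value near compound 2 but with wide uncertainty, and the step of a 2.3-fold higher number from compound 2 to compound 3 (0.36 log units; beyond the scatter) is estimated to be modest. Compound 3 is expected to give 60 nM, within the range 10 nM to 400 nM.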

Compound 3, half-maximal inhibitory concentration: 50 nM
Compound 3: the middle estimate sits 1.2-fold (0.08 log units) above what was measured, and the stated range covers the measured number.
By their numbers in this assay, from the lowest: compounds 2 and 3 (each within the scatter of the next); then compound 1.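

In this assay, 1,2-oxazol-3-yl in place of methoxycarbonyl on this oxygen gives a 1.9-fold higher number from compound 2 to compound 3 (0.28 log units; within the scatter) and so leaves the two compounds indistinguishable here, although one cap has no ring and the other is a five-membered aromatic ring. The strong gain over the free hydroxymethyl compound is therefore not unique to methoxycarbonyl: putting the ring on that oxygen in place of hydrogen also gives a 26-fold lower number from compound 1 to compound 3 (1.41 log units; beyond the scatter) as a large step, so two quite different caps now reach a similar level. The data on hand give no explanation for why either cap has this effect.

The two caps have the same counts of hydrogen-bond donors and acceptors, and two examples cannot show whether those shared counts matter, so a plain methyl or a benzyl group on the same oxygen would be the informative comparison. Also open, on these data alone, is how far this tolerance extends, for instance to a longer chain such as ethoxycarbonyl, to a phenyl ring, or to an amine in place of the oxygen.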